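Ring methyl on the aryl propanoic acid series

A few compounds are considered here, and "the series" means these few. Any claim that something is new, unique, unknown or untested is made for them only; others in the source may bear on it.

Measured so far:
compound 1 `O=C(O)CCc1ccc(OCc2ccccc2SC(F)(F)F)cc1` — 74%
compound 2 `CC(CC(=O)O)c1ccc(OCc2ccccc2SC(F)(F)F)cc1` — 109%

In a functional assay on cells for agonist activity at Free fatty acid receptor 1 (Homo sapiens), read by FLIPR and calcium flux (a higher number here means a larger maximal response, a lower number a smaller maximal response), compound 1 gives 74%, the lowest of the two numbers; compound 2 gives 109%. Among the measured compounds shown here, the only measured step is a number 35 percentage points higher from compound 1 to compound 2 (beyond the scatter). Compound 3 `Cc1cc(CCC(=O)O)ccc1OCc1ccccc1SC(F)(F)F` differs from compound 1 by methyl in place of hydrogen on an aromatic carbon. This change sits on an aromatic carbon, ortho to a large group and meta to the 2-carboxyethyl group, not on the saturated chain where the measured methyl was added, so that step is only a loose guide here. A modest rise is expected, a number 11 percentage points higher from compound 1 to compound 3 (beyond the scatter). Compound 3 is estimated at 85%, between 60% and 110%.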

Compound 3, largest response reached (reported as percent of maximum), in percent of the reference or control that the assay uses: 81%
For compound 3 the middle estimate is 4 percentage points above the measured one; the measured number falls inside the stated range.
By their numbers in this assay, from the lowest: compounds 1 and 3 (each within the scatter of the next); then compound 2.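

Methyl in place of hydrogen on an aromatic carbon, ortho to a large group and meta to a 2-carboxyethyl group, gives a number 7 percentage points higher from compound 1 to compound 3 (within the scatter) in this assay and so leaves the maximal response of compound 1 unchanged within the scatter. The step of a number 35 percentage points higher from compound 1 to compound 2 (beyond the scatter) seen with methyl on the saturated chain does not carry over to this aromatic carbon. No evidence here bears on this difference between the two methyl sites. Open, as far as these compounds go, is whether an ethyl, a methoxy or a chlorine on this aromatic carbon would match methyl. Also open, from the compounds shown here alone, is what the aromatic methyl and the chain methyl do together on one compound.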